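The compounds below may be only part of what the source reports. "The series", "measured", "known", "first", "only" and "open" are said of these compounds alone.

Working notes on the series. Compound 3 `COc1ccc2[nH]c3c(c2c1)CCNC31CCN(Cc2ccc(F)c(F)c2)CC1` stands with the highest number of the three measured in an assay on FRT cells for positive allosteric modulation of Cystic fibrosis transmembrane conductance regulator variant N1303K (Homo sapiens), in the presence of a further agent that is not named here; a lower number here means that less compound is needed, a higher number that more compound is needed for the effect; compound 3 gives 11000 nM, while compound 2 `COc1ccc2[nH]c3c(c2c1)CCNC31CCN(Cc2ccc(F)c(Cl)c2F)CC1` gives 4500 nM and compound 1 `COc1ccc2[nH]c3c(c2c1)CCNC31CCN(Cc2ccc(Br)cc2F)CC1` gives 1600 nM. The measured steps run a 2.8-fold higher number from compound 1 to compound 2 (0.45 log units; beyond the scatter), a 6.9-fold higher number from compound 1 to compound 3 (0.84 log units; beyond the scatter) and a 2.4-fold higher number from compound 2 to compound 3 (0.39 log units; beyond the scatter), each a change of the halogen pattern on the aryl group; a halogen-free ring with a ring nitrogen has not been measured. Compound 4 `COc1ccc2[nH]c3c(c2c1)CCNC31CCN(Cc2cccnc2)CC1` differs from compound 3 by pyridin-3-yl in place of 3,4-difluorophenyl on a saturated chain carbon bound to an amine nitrogen in a ring. Going by the values given here, no measured step bears directly on this change; the three steps only show that every change away from compound 1 raised the number. For compound 4 a step of a 1.8-fold higher number from compound 3 to compound 4 (0.26 log units; within the scatter) is expected, toward a higher number. Compound 4 is therefore estimated at 20000 nM, within 7000 nM to 60000 nM.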

Compound 4, half-maximal effective concentration: 17000 nM
Compound 4: the middle estimate sits 1.2-fold (0.07 log units) above what was measured; the range from low to high includes it.
By their numbers in this assay, from the lowest: compound 1; then compound 2; then compounds 3 and 4 (each within the scatter of the next).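

Pyridin-3-yl in place of 3,4-difluorophenyl, on a saturated chain carbon bound to an amine nitrogen in a ring, gives a 1.5-fold higher number from compound 3 to compound 4 (0.19 log units; within the scatter) in this assay; at this position, the halogen-free ring with a ring nitrogen is not told apart from 3,4-difluorophenyl. The same ring is separated from the other two aryl groups, with a 3.8-fold higher number from compound 2 to compound 4 (0.58 log units; beyond the scatter) and an 11-fold higher number from compound 1 to compound 4 (1.03 log units; beyond the scatter), and compound 1 keeps the lowest number of the four. No evidence on the cause of these differences accompanies the series.

Open, from the compounds shown here alone, is whether a bromine on the pyridin-3-yl ring would bring the number toward that of compound 1, and how an amine or a carboxylic acid on the aryl ring would read.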